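This account rests on a few compounds, and the source may have more. Where it says the series, first, only, none or still open, it means among the compounds named here.

Measured so far in an ADME assay on a cell-free system (plasma, Homo sapiens) for metabolic stability, read by LC-MS; on this read-out lower numbers stand for a shorter-lived compound and higher numbers for a longer-lived compound:
compound 1 `COC(=O)c1cccc(-c2cc(C(=O)Nc3ccncc3)ccc2CN)c1`: 1.52 h
compound 2 `COC(=O)c1cccc(-c2cc(C(=O)Nc3ccncc3F)ccc2CN)c1`: 1.08 h

Compound 1 carries the higher of the two numbers in this assay, but the gap to compound 2, a 1.4-fold lower number from compound 1 to compound 2 (0.15 log units; within the scatter), is within the scatter, so the two compounds are not separated. Compound 3 `CCOC(=O)c1cccc(-c2cc(C(=O)Nc3ccncc3)ccc2CN)c1` differs from compound 1 by methyl in place of hydrogen on a saturated chain carbon bound to an oxygen next to a carbonyl group. Among the measured compounds shown here, no measured pair changes the methoxycarbonyl group; the only measured step, fluoro in place of hydrogen on an aromatic carbon, sits elsewhere on the shared core and was itself within the scatter, so it gives no direction for a change at the methoxycarbonyl group. With nothing to set a direction, no step beyond the scatter is expected in this assay from compound 1 to compound 3, the expected step being a 1.2-fold higher number from compound 1 to compound 3 (0.07 log units; within the scatter). Compound 3 is therefore estimated at 1.8 h, with a range of 0.9 h to 3.6 h.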

Compound 3, half-life: 0.683 h
Beside the measured number, compound 3's estimate is 2.6-fold (0.42 log units) above it, outside the stated range (below it).
By their numbers in this assay, from the lowest: compounds 3, 2 and 1 (each within the scatter of the next, the first and the last beyond it).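

In this assay, among the compounds shown here, methoxycarbonyl to ethoxycarbonyl gives the first step that lies beyond the scatter (a 2.2-fold lower number from compound 1 to compound 3 (0.35 log units; beyond the scatter)), and it points to a shorter-lived compound. The fluoro step (a 1.4-fold lower number from compound 1 to compound 2 (0.15 log units; within the scatter)) elsewhere on the shared core stayed within the scatter, so the methoxycarbonyl position is so far the only place shown to shift the half-life, on a single pair and by a modest amount. No available finding accounts for this step.

Going by these compounds, whether the trend continues with a longer chain such as propoxycarbonyl or a branched one such as isopropoxycarbonyl remains open, as does the reading of a carboxylic acid or a primary amide at this position in this assay. Also open, on these data alone, is whether ethoxycarbonyl gives a similar step when fluoro is present on the shared core.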